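Swapping one end of a side chain on compound 2

A few compounds are considered here, and "the series" means these few. Any claim that something is new, unique, unknown or untested is made for them only; others in the source may bear on it.

compound 1 `Oc1c(Cl)cc(Cn2c(C3CC3)nc3cccnc32)cc1Cl` gives 20 nM here
compound 2 `CCc1nc2c(C)ccnc2n1Cc1ccc(-c2ccccc2C(=O)O)cc1` gives 1.26 nM here

In a functional assay (aorta) with Oryctolagus cuniculus as the target (a higher number here means weaker binding, a lower number tighter binding), compound 2 has the lower of the two numbers at 1.26 nM and lies beyond the usual scatter from compound 1. Compound 3 `COCc1nc2c(C)ccnc2n1Cc1ccc(-c2ccccc2C(=O)O)cc1` differs from compound 2 in one place: methoxy in place of methyl on a saturated chain carbon bound to an aromatic carbon turns ethyl into methoxymethyl, with methoxy in place of methyl on a saturated chain carbon bound to an aromatic carbon. Within the data shown here, no measured pair shows this change, so the expectation is loose: a small rise in the number, meaning somewhat weaker binding, with a 2.0-fold higher number from compound 2 to compound 3 (0.30 log units; within the scatter) as the estimated step. The estimate for compound 3 is 2.5 nM within an expected range of 0.8 nM to 8 nM in this measurement.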

Compound 3, dissociation constant: 79.4 nM
Estimate against measurement, compound 3: 32-fold (1.50 log units) below, outside the stated range (above it).
By their numbers in this assay, from the lowest: compound 2; then compound 1; then compound 3.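

In this assay the swap from ethyl to methoxymethyl gives a 63-fold higher number from compound 2 to compound 3 (1.80 log units; beyond the scatter) and so shows that this position responds strongly to what sits at the end of the chain. Methoxy in place of methyl is a modest edit on paper, yet it is enough to take the number well beyond the scatter. Nothing measured here explains why the step is so large.

On these data alone, it remains open whether an amine or a hydroxyl at this place, or a longer chain such as propyl, would behave like ethyl or like methoxymethyl.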